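Methyl for methoxy on the carbonyl of compound 2

This account rests on a few compounds, and the source may have more. Where it says the series, first, only, none or still open, it means among the compounds named here.

Compound 1 `COC(=O)N1CCN(CCN2CCC(CNC(=O)c3cccc4[nH]c(C(C)C)nc34)CC2)CC1`: > 1.5 h (a limit)
Compound 2 `COC(=O)N(C)CC(O)CN1CCC(CNC(=O)c2cccc3[nH]c(C(C)C)nc23)CC1`: 1.32 h

These values come from an ADME assay on microsomes from liver (Rattus norvegicus) for metabolic stability (on this read-out higher numbers stand for a longer-lived compound and lower numbers for a shorter-lived compound), and are the only two available for the series. Within the data shown here, compound 2 gives 1.32 h as the sole exact number. For compound 1 the reading > 1.5 h is a limit.

Compound 3 `CC(=O)N(C)CC(O)CN1CCC(CNC(=O)c2cccc3[nH]c(C(C)C)nc23)CC1` differs from compound 2 by methyl in place of methoxy on a carbonyl carbon. Among the measured compounds shown here, the methoxycarbonyl group is present in both measured compounds, so no measured step replaces it. For the measured compounds named here, the one measured step is an at least 1.1-fold lower number from compound 1 to compound 2 (0.05 log units; that floor lies within the scatter) and it concerns a different change in the side chain. That step gives no size or direction for the present change, and it offers no reason to expect a move beyond the scatter.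

The expected step is a 1.0-fold lower number from compound 2 to compound 3 (0.01 log units; within the scatter) and no direction is favoured. Compound 3 is estimated at 1.3 h with an expected range from 0.7 h to 2.2 h in this assay.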

Compound 3, half-life: > 1.5 h
Compound 3: no number, only a limit; the forecaster's own chance of this, stated with the estimate: 30%; middle value at least 1.1-fold (0.06 log units) from the limit.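

In this assay, methyl in place of methoxy on a carbonyl carbon gives an at least 1.1-fold higher number from compound 2 to compound 3 (0.05 log units; that floor lies within the scatter). For this position, the new information is that the methoxycarbonyl group is not needed to keep the half-life at this level: acetyl(methyl)amino in place of (methoxycarbonyl)(methyl)amino shows no sign of a shorter-lived compound, although the floor of the step does not establish a real gain. The reading for compound 3 is a limit and not a number, so the true size of the change remains unknown, and the step from compound 1 to compound 3 cannot be read, leaving no order among the longest-lived compounds: the limit of > 1.5 h in this assay, at which 2 of the 3 values shown sit.

Still open, going by these compounds, is whether other groups on this carbonyl carbon, such as dimethylamino, cyclopropyl or a longer chain such as propyl, would hold the half-life at the same level. Also open, on these data alone, is whether the same swap to acetyl would give a similar reading on the (4-(methoxycarbonyl)piperazin-1-yl)methyl side chain of compound 1, where the methoxycarbonyl group sits in a different setting.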